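The compounds below may be only part of what the source reports. "The series", "measured", "known", "first", "only" and "open" are said of these compounds alone.

Compound 3 `COc1ccc(-c2cc(C(=O)Nc3ccc(Oc4ccnc5[nH]ccc45)cc3)ncn2)cc1` is one of three analogues that share a core and differ in the group on the outer phenyl ring and in the arrangement of the attached heteroaromatic ring. In a functional assay on MCF7 cells (Homo sapiens) for cytotoxicity, read by MTT assay, with a stated time of 72 h (on this read-out lower numbers stand for stronger inhibition and higher numbers for weaker inhibition), compound 3 gives 4450 nM, the lowest of the two numbers available. Compound 1 `Cc1ccc(-c2ccnc(C(=O)Nc3ccc(Oc4ccnc5[nH]ccc45)cc3)n2)cc1` stands closest, giving 6410 nM in this assay, a gap that lies within the usual scatter, so the two cannot be ordered. Compound 2 `O=C(Nc1ccc(Oc2ccnc3[nH]ccc23)cc1)c1nccc(-c2ccc(F)cc2)n1`, which carries a fluoro group but a different heteroaromatic arrangement, is reported in this assay as "not active" (no number reported), with no number attached.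

Compound 4 `O=C(Nc1ccc(Oc2ccnc3[nH]ccc23)cc1)c1cc(-c2ccc(F)cc2)ncn1` is the untested member. It differs from compound 3 in one place: fluoro in place of methoxy on an aromatic carbon. For the measured compounds named here, no measured pair in this set isolates that change, so the expected size of the step cannot be read from a neighbouring pair. Going by the values given here, the only compound that already bears fluoro, compound 2, yielded no number in this assay, which suggests caution rather than a direction. The step from compound 3 to compound 4 is expected to be modest and to lean toward a higher number, a 2.0-fold higher number from compound 3 to compound 4 (0.31 log units; beyond the scatter). Compound 4 is therefore estimated at 9000 nM in this assay, within a range from 3000 nM to 30000 nM.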

Compound 4, half-maximal inhibitory concentration: 15900 nM
Estimate against measurement, compound 4: 1.8-fold (0.25 log units) below; low and high end bracket the measured number.
By their numbers in this assay, from the lowest: compounds 3 and 1 (each within the scatter of the next); then compound 4.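

In this assay, for the compounds shown here, the change from 4-methoxyphenyl to 4-fluorophenyl brings a 3.6-fold higher number from compound 3 to compound 4 (0.55 log units; beyond the scatter) and gives the set its only measured step at a single place, showing that this position, para to a large group, is not indifferent to the group it carries. Compound 4 gives 15900 nM in this assay and so shows that a fluoro group on the outer ring can still yield a number, whereas compound 2, which has the same group with a different heteroaromatic arrangement, is reported as "not active". No measurement shown here explains why the number rises with this change and the step therefore stands as an observation only.

With only methoxy and fluoro compared at this position on this arrangement, the shown compounds cannot separate what losing methoxy contributes from what gaining fluoro contributes. As far as these compounds go, it remains open how an amine, a chloro group, a carboxylic acid or a longer alkoxy chain would behave here, and whether the same step would hold on the heteroaromatic arrangement of compound 1.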